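The source may report more compounds than this note shows. Statements on the series, on what has been measured and on what is new or still open speak of the compounds shown alone.

Measured in a physicochemical assay for lipophilicity, read by HPLC, with a stated time of 90 min, tested at 100 uM; a lower number here means a more polar compound, a higher number a more lipophilic compound:
- compound 1 `O=C(Nc1ccc(OC(F)(F)F)cc1)NC1CCN(C(=O)C2CCOCC2)CC1`: 3.26
- compound 2 `O=C(Nc1ccc(OC(F)(F)F)c(F)c1)NC1CCN(C(=O)C2CCOCC2)CC1`: 3.73
- compound 3 `O=C(Nc1ccc(C(F)(F)F)cc1)NC1CCN(C(=O)c2ccoc2)CC1`: 3.5

Compound 1 at 3.26 lies within the usual scatter of compound 3 at 3.5, while compound 2 stands clear of it at 3.73.

The next compound is compound 4 `O=C(Nc1ccc(OC(F)(F)F)cc1)NC1CCN(C(=O)C2CCCOC2)CC1`, which has the same atoms as compound 1, joined differently: oxan-3-yl in place of oxan-4-yl on a carbonyl carbon. The change is oxan-3-yl in place of oxan-4-yl on a carbonyl carbon.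

For the measured compounds named here, only one measured step is available, a number 0.47 log units higher from compound 1 to compound 2 (beyond the scatter). It is a fluoro in place of hydrogen on an aromatic carbon, a different change at a different place, so it gives no direct guide to size or direction. Going by the values given here, compound 3 differs from compound 1 in more than one place and gives no clean step. Among the compounds with values here, no measured pair covers the oxan-3-yl for oxan-4-yl swap.

In this assay the expected result is a number 0.09 log units higher from compound 1 to compound 4 (within the scatter), so no step beyond the scatter is anticipated. For compound 4 the estimated value is 3.35, with an expected range from 3.05 to 3.65.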

Compound 4, partition coefficient: 3.42
Beside the measured number, compound 4's estimate is 0.07 log units below it, and the stated range covers the measured number.
By their numbers in this assay, from the lowest: compounds 1, 4, 3 and 2 (each within the scatter of the next, the first and the last beyond it).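

With oxan-3-yl in place of oxan-4-yl on a carbonyl carbon, this assay gives a number 0.16 log units higher from compound 1 to compound 4 (within the scatter) and so does not separate these two groups of identical atoms at this place. For the compounds shown here, the only earlier single-place step, a number 0.47 log units higher from compound 1 to compound 2 (beyond the scatter) for fluoro in place of hydrogen on an aromatic carbon, is the one printed beyond the scatter, so the series now has a first reading at the carbonyl carbon, and this swap stays within the scatter. No supporting measurement accounts for this result.

As far as these compounds go, whether this place responds to a group of another kind, such as an amine, a carboxylic acid or an open alkyl chain in place of oxan-4-yl, remains open. Also open, from the compounds shown here alone, is whether the swap reads the same with the fluoro group of compound 2 present.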